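From compound 2 to its 4-bromophenyl analogue

The compounds below may be only part of what the source reports. "The series", "measured", "known", "first", "only" and "open" are said of these compounds alone.

Values from an ADME assay on cells (Fibroblast, Homo sapiens) for cytotoxicity, with a stated time of 48 h (a lower number here means a stronger inhibitor, a higher number a weaker inhibitor), follow, and each one is a limit of the assay and not a number:
Compound 1 `COc1cc(O)c(C(=O)/C=C/c2ccc(F)cc2)c(OC)c1` gives > 20000 nM 
Compound 2 `COc1cc(OC)c(C(=O)/C=C/c2ccccc2)c(OC)c1` gives > 20000 nM 
Compound 3 `COc1cc(O)c(C(=O)/C=C/c2ccccc2OC)c(OC)c1` gives > 20000 nM 

Compound 2 stands at > 20000 nM and this entry is a limit and not a number. The other two compounds offer no number either, and the whole set rests on one mark: the limit of > 20000 nM in this assay, at which 3 of the 3 values shown sit, and so the three compounds cannot be ranked against one another.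

Compound 4 `COc1cc(OC)c(C(=O)/C=C/c2ccc(Br)cc2)c(OC)c1` differs from compound 2 in one place: bromo in place of hydrogen on an aromatic carbon and in words this is bromo in place of hydrogen on an aromatic carbon, or phenyl to 4-bromophenyl. Within the data shown here, no pair of measured compounds differs in one place, so no measured step guides this change. The expectation in this assay is therefore for no step beyond the scatter, or a modest move towards a lower number, and this rests on compound 2 at > 20000 nM as a starting point. The expected size is a number no higher from compound 2 to compound 4 (the limit leaves the size open) as an estimate only. For compound 4 the estimated value is 20000 nM with an expected range from 9000 nM to 40000 nM in this assay and a reading at the limit is the likeliest outcome.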

Compound 4, half-maximal inhibitory concentration: > 20000 nM
Compound 4: no number, only a limit; the forecaster's own chance of this, stated with the estimate: 70%; the middle value lies on the limit itself.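

In this assay compound 4 gives > 20000 nM, which is a limit of the assay and not a number. Compound 2 also stands at a limit, so no step can be read between compound 2 and compound 4, and the set rests on a single mark: the limit of > 20000 nM in this assay, at which 4 of the 4 values shown sit. The compounds shown leave open how the four rank against one another and whether bromo in place of hydrogen changes the read-out at all.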